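A few compounds are considered here, and "the series" means these few. Any claim that something is new, unique, unknown or untested is made for them only; others in the source may bear on it.

Measured so far in a functional assay on K562 cells (Homo sapiens) for cytotoxicity, read by MTT assay, with a stated time of 5 days; on this read-out higher numbers stand for weaker inhibition and lower numbers for stronger inhibition:
Compound 1 `COc1ccc(Cn2nncc2-c2cc(OC)c(OC)c(OC)c2)cc1Br` gives > 10000 nM, which is a limit of the assay rather than a number.
Compound 2 `COc1ccc(Cn2nncc2-c2cc(OC)c(OC)c(OC)c2)cc1O` gives 1830 nM.
Compound 3 `COc1ccc(-c2cnnn2Cc2cc(OC)c(OC)c(OC)c2)cc1Br` gives > 10000 nM, again a limit of the assay and not a number.

Within this series one change has already been measured: hydroxy in place of bromo on an aromatic carbon, giving an at least 5.4-fold lower number from compound 1 to compound 2 (0.73 log units; beyond the scatter). Compound 3 and compound 1 are built from the same atoms joined differently; the difference between the two cores is not broken down here. Compound 4 `COc1ccc(-c2cnnn2Cc2cc(OC)c(OC)c(OC)c2)cc1O` carries the same change on the core of compound 3: hydroxy in place of bromo on an aromatic carbon. As the value of compound 3 is only a limit, the step to compound 4 cannot be fixed closely, but a gain of the same kind is expected, an at least 3.3-fold lower number from compound 3 to compound 4 (0.52 log units; beyond the scatter), resting on an at least 5.4-fold lower number from compound 1 to compound 2 (0.73 log units; beyond the scatter). Compound 4 is therefore estimated at 3000 nM, between 800 nM and 10000 nM.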

Compound 4, half-maximal inhibitory concentration: 530 nM
Compound 4: middle estimate off by 5.7-fold (0.75 log units), on the high side; measured number below the stated range.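

In this assay hydroxy in place of bromo on an aromatic carbon gives an at least 18-fold lower number from compound 3 to compound 4 (1.27 log units; beyond the scatter) and so points the same way on the core of compound 3 as on the core of compound 1. Going by these compounds, the value of compound 3 of > 10000 nM is a limit of the assay and not a number, and the true size of this step stays unknown. The data show that the direction of the change carries across these two cores, but not whether its size does: the same change on two cores in this assay, an at least 5.4-fold lower number (0.73 log units; beyond the scatter) from compound 1 to compound 2 and an at least 18-fold lower number (1.27 log units; beyond the scatter) from compound 3 to compound 4; the limit leaves it open whether they differ

The compounds shown leave open whether an amine or a carboxylic acid on the same aromatic carbon would do as well as hydroxy. Going by these compounds alone, with only two cores in view, they also leave open whether the gain would hold on a third core.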